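The source may report more compounds than this note shows. Statements on the series, on what has been measured and on what is new or still open speak of the compounds shown alone.

Measured compounds:
Compound 1 `O=C(O)C1(Sc2nccc3ncccc23)CCC1` gives > 10000 nM in an assay on HEK293 cells for inhibition of solute carrier family 22 member 12 (Homo sapiens), read by scintillation counting, with a stated time of 12 min (on this read-out lower numbers stand for stronger inhibition and higher numbers for weaker inhibition), which is a limit of the assay and not a number.
Compound 2 `Nc1ccc2nccc(SC3(C(=O)O)CCC3)c2c1` gives 1790 nM in this assay.

Compound 2 therefore holds the only number shown; the other value, that of compound 1, is a limit (the limit of > 10000 nM in this assay, at which 1 of the 2 values shown sits). Compound 3 `N#CCOc1ccc2nccc(SC3(C(=O)O)CCC3)c2c1` has not yet been measured. It differs from compound 2 in one place: cyanomethoxy in place of amino on an aromatic carbon. Among the compounds with values here, no pair of measured compounds differs in a single place, so no measured step is available to anchor this change. Within the data shown here, the group on that aromatic carbon is the only point at which compound 1 and compound 2 differ from each other, and the two values show that the amino compound gives a number while the bare compound gives a limit. For compound 3 a step of a 1.2-fold lower number from compound 2 to compound 3 (0.08 log units; within the scatter) is expected, within the usual scatter, and compound 3 is estimated at 1500 nM with a range from 350 nM to 6000 nM.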

Compound 3, half-maximal inhibitory concentration: 680 nM
For compound 3 the middle estimate is 2.2-fold (0.34 log units) above the measured one; measured number inside the range.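

Within the data shown here, the first measured step at this position comes from the change to cyanomethoxy in place of amino on the aromatic carbon: in this assay it gives a 2.6-fold lower number from compound 2 to compound 3 (0.42 log units; beyond the scatter), a modest change but one that lies beyond the usual scatter. An amino group on that carbon is therefore not required for a measurable number, since the cyanomethoxy group of compound 3 has 0 hydrogen-bond donors and is larger by heavy-atom count. Compound 1 remains a limit of the assay and not a number, so steps to it cannot be read: the limit of > 10000 nM in this assay, at which 1 of the 3 values shown sits.

The single change alters the oxygen, the chain and the nitrile together, so the compounds shown do not separate their contributions. Going by these compounds, whether a methoxy group without the nitrile, or a longer chain ending in a nitrile, would give a similar step remains open.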